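Swapping phenoxy for dimethylamino: what to expect for cytotoxicity

This account rests on a few compounds, and the source may have more. Where it says the series, first, only, none or still open, it means among the compounds named here.

Measured so far:
compound 1 `COc1cc(C)cc(-c2c(-c3ccnc(-c4ccc(C(C)=O)cc4)c3)cnn2CC#N)c1` gives 93%
compound 2 `COc1cc(C)cc(-c2nn(CC#N)cc2-c2ccc(-c3cccc(C(C)=O)c3)nc2)c1` gives 88%
compound 3 `Cc1cc(O)cc(-c2nn(CC#N)cc2-c2ccnc(-c3ccc(Oc4ccccc4)cc3)c2)c1` gives 88%

All three compounds were tested in a functional assay on SN12C cells (Homo sapiens) for cytotoxicity, read by sulforhodamine B assay, with a stated time of 48 h, tested at 0.01 uM; on this read-out lower numbers stand for a stronger effect and higher numbers for a weaker effect at the one concentration tested. The three numbers sit close together. Compound 3 shows the same digits as compound 2, and compound 1 differs from compound 3 by an amount that stays within the usual scatter of repeated measurements, so none of the three can be called stronger or weaker than another on this evidence. Among the compounds with values here, in short, every compound measured so far leaves most of the cells alive at the single concentration used.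

Compound 4 `Cc1cc(O)cc(-c2nn(CC#N)cc2-c2ccnc(-c3ccc(N(C)C)cc3)c2)c1` is the next compound to be measured. It shares the core of compound 3 and differs from it in one spot: dimethylamino in place of phenoxy on an aromatic carbon. Within the data shown here, no pair of measured compounds differs in a single place, so there is no directly comparable step to lean on; the expectation rests on the narrow spread of the three numbers alone.

On that basis the step of a number 1 percentage points higher from compound 3 to compound 4 (within the scatter) is expected to be small, with no direction beyond the scatter. For compound 4 the estimate in this assay is 89%, with a range from 76% to 100%.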

Compound 4, a percentage reported as activity, at one concentration (the size of the read-out at that concentration, not a potency): 90%
For compound 4 the middle estimate is 1 percentage points below the measured one; low and high end bracket the measured number.
By their numbers in this assay, from the lowest: compounds 2, 3, 4 and 1 (each within the scatter of the next).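

Within the data shown here, the first comparison in this set that differs in a single place comes from this assay, where dimethylamino in place of phenoxy on an aromatic carbon, para to a large group, gives a number 2 percentage points higher from compound 3 to compound 4 (within the scatter) and so leaves the read-out within the usual noise of the measurement. This means that a group with 7 heavy atoms and an aromatic ring can give way to one with 3 heavy atoms and no ring without a measurable effect at this position, at the single low concentration tested. No measured property of these compounds is available to explain this result.

Going by these compounds, whether a carboxylic acid, a primary amine or a morpholine ring on the same aromatic carbon would shift the read-out remains open, since the two groups compared here cover only a small part of what could sit there. Also unresolved is whether compound 3 and compound 4 would still look alike at higher concentrations, where a stronger effect on the cells might appear and small differences between the two groups could become visible.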